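Aryl amide swap at the shared core: compound 4

The source may report more compounds than this note shows. Statements on the series, on what has been measured and on what is new or still open speak of the compounds shown alone.

The shared core of compound 1 `O=C(Nc1ccccn1)c1c(O)c2cccnc2n(-c2ccccc2)c1=O` carries an amide whose nitrogen bears a pyridin-2-yl group. For the measured compounds named here, in a functional assay on the whole organism for inhibition, with Rattus norvegicus as the target, read by cytopathic effect and paw edema, at a dose of 100 mg/kg by the oral route (a higher number here means more inhibition at the dose given (going by the name of the read-out), a lower number less inhibition), compound 1 gives 14.6%, the second highest of the three numbers measured so far. Compound 2 `CCCCNC(=O)c1c(O)c2cccnc2n(-c2ccccc2)c1=O` gives 20.4% in this assay, and the step of a number 5.8 percentage points higher from compound 1 to compound 2 (within the scatter) lies within the scatter. Compound 3 `COc1ccc(NC(=O)c2c(O)c3cccnc3n(-c3ccccc3)c2=O)cc1` gives -1.9%, and the step of a number 16.5 percentage points lower from compound 1 to compound 3 (beyond the scatter) goes beyond it; the step of a number 22.3 percentage points lower from compound 2 to compound 3 (beyond the scatter) also goes beyond it.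

Compound 4 `O=C(Nc1cccc(Cl)c1)c1c(O)c2cccnc2n(-c2ccccc2)c1=O` differs from compound 1 by 3-chlorophenyl in place of pyridin-2-yl on an amide-type nitrogen. Going by the values given here, of the measured steps, the one from compound 1 to compound 3 bears most directly on this change, since there too a carbon-only aromatic ring took the place of the pyridin-2-yl group, and that step was modest but beyond the scatter in the downward direction; the step from compound 1 to compound 2 shows that leaving the pyridin-2-yl group need not lower the number. The expected step is therefore a lowering, a number 9.6 percentage points lower from compound 1 to compound 4 (within the scatter), with considerable uncertainty. For compound 4 the estimate in this assay is 5%, expected to fall between -12% and 20%.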

Compound 4, a percentage reported as inhibition, in the whole organism at one dose (the size of the read-out at that dose, not a potency): 13.4%
Beside the measured number, compound 4's estimate is 8.4 percentage points below it, and the stated range covers the measured number.
By their numbers in this assay, from the lowest: compound 3; then compounds 4, 1 and 2 (each within the scatter of the next).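

The step of a number 1.2 percentage points lower from compound 1 to compound 4 (within the scatter) shows that a ring of carbon only on the amide-type nitrogen does not by itself bring the number down in this assay, which compound 3 alone had left possible. The step of a number 15.3 percentage points higher from compound 3 to compound 4 (beyond the scatter) shows instead that two such rings can part beyond the scatter at this place, so the ring type alone does not set the number. The step of a number 7 percentage points lower from compound 2 to compound 4 (within the scatter) also puts the 3-chlorophenyl amide within the scatter of the butyl amide, as the pyridin-2-yl amide already was.

The compounds shown leave open how a carboxylic acid or an amine on the aryl ring, or a chain longer than butyl on the nitrogen, would read in this assay. Nothing measured here explains any of these steps.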